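This account rests on a few compounds, and the source may have more. Where it says the series, first, only, none or still open, it means among the compounds named here.

Of the compounds shown here, three from this series have been tested in a functional assay on SNB-75 cells (Homo sapiens) for inhibition, read by sulforhodamine B assay, with a stated time of 48 h, tested at 0.1 uM; on this read-out higher numbers stand for a weaker effect at the one concentration tested and lower numbers for a stronger effect. Compound 1 `COc1cc(Cl)cc(-c2nn(-c3cccc(NC(=O)Nc4ccc(Cl)c(C(F)(F)F)c4)c3)cc2-c2ccncc2)c1` gives 52%. Compound 2 `COc1cc(Cl)cc(-c2nn(-c3cccc(NC(=O)Nc4ccc(Cl)c(Cl)c4)c3)cc2-c2ccncc2)c1`, in this assay, gives 90%. Compound 3 `COc1cc(Cl)cc(-c2nn(-c3cccc(NC(=O)Nc4cccc(C(F)(F)F)c4)c3)cc2-c2ccncc2)c1` gives 55% in this assay, and so stands second highest of the three numbers: its nearest neighbour is compound 1, the difference being a number 3 percentage points higher from compound 1 to compound 3 (within the scatter), while the larger gap is a number 35 percentage points lower from compound 2 to compound 3 (beyond the scatter).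

Compound 4 `COc1cc(Cl)cc(-c2nn(-c3cccc(NC(=O)c4cccc(C(F)(F)F)c4)c3)cc2-c2ccncc2)c1` differs from compound 3 in one place: 3-(trifluoromethyl)phenyl in place of (3-(trifluoromethyl)phenyl)amino on a carbonyl carbon. Among the measured compounds shown here, none of the measured steps touches this position. The steps seen so far, a number 38 percentage points higher from compound 1 to compound 2 (beyond the scatter) and a number 35 percentage points lower from compound 2 to compound 3 (beyond the scatter), both concern the substituents of the terminal aromatic ring, and the small one, a number 3 percentage points higher from compound 1 to compound 3 (within the scatter), does the same. They show that this assay can move widely with changes in that part of the molecule, but they give no direct guide to a change at the carbonyl carbon itself, which is what separates compound 3 from compound 4.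

For the measured compounds named here, with no precedent, compound 4 is expected to lie near compound 3 or somewhat weaker, the estimated step being a number 10 percentage points higher from compound 3 to compound 4 (within the scatter). The number estimated for compound 4 in this assay is 65%, within a range from 45% to 90%.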

Compound 4, a percentage reported as activity, at one concentration (the size of the read-out at that concentration, not a potency): 54%
Compound 4: the middle estimate sits 11 percentage points above what was measured, and the stated range covers the measured number.
By their numbers in this assay, from the lowest: compounds 1, 4 and 3 (each within the scatter of the next); then compound 2.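

In this assay, putting 3-(trifluoromethyl)phenyl in place of (3-(trifluoromethyl)phenyl)amino on the carbonyl carbon gives a number 1 percentage points lower from compound 3 to compound 4 (within the scatter), so this first change at the carbonyl carbon itself, which takes out the nitrogen and its hydrogen-bond donor, leaves no difference that this read-out can resolve for this pair. Among the compounds shown here, compound 4 also stays level with the chloro-bearing urea, with a number 2 percentage points higher from compound 1 to compound 4 (within the scatter), while the one compound that stands apart remains the 3,4-dichlorophenyl urea, with a number 36 percentage points lower from compound 2 to compound 4 (beyond the scatter), so the only large steps in the set still involve compound 2. The data shown offer nothing that explains why the nitrogen can go without a visible change in the read-out.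

From the compounds shown here alone, the loss of the nitrogen has been read on one terminal ring only, at one concentration, so it stays open whether the same holds with the 3,4-dichlorophenyl or 4-chloro-3-(trifluoromethyl)phenyl groups, where the ureas themselves differ so widely. Going by these compounds, it is also open how the read-out responds when a methylene or an ether oxygen takes the place of the amino nitrogen on the carbonyl carbon.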